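Opening the Amide of Compound 3 into a Sulfonamide Chain

The compounds below may be only part of what the source reports. "The series", "measured", "known", "first", "only" and "open" are said of these compounds alone.

Measured in an assay on HEK293 cells for displacement of a labelled ligand from NPC1-like intracellular cholesterol transporter 1 (Homo sapiens); a higher number here means a weaker inhibitor, a lower number a stronger inhibitor:
compound 1 `CCOC(=O)C1CCN(C(=O)CN2CN(c3ccccc3)C3(CCN(C(=O)c4ccc(C(C)(C)C)cc4)CC3)C2=O)CC1` gives 3100 nM
compound 2 `CC1(C)CC(OC(=O)CN2CN(c3ccccc3)C3(CCN(C(=O)c4ccc(C(C)(C)C)cc4)CC3)C2=O)CC(C)(C)N1` gives 1300 nM
compound 3 `CC(C)(C)c1ccc(C(=O)N2CCC3(CC2)C(=O)N(CC(=O)N2CCCCC2CCO)CN3c2ccccc2)cc1` gives 6100 nM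

Compound 3 has the highest of the three numbers. The nearest of the others stands a 2.0-fold higher number from compound 1 to compound 3 (0.29 log units; within the scatter), a gap within the scatter; the furthest stands a 4.7-fold higher number from compound 2 to compound 3 (0.67 log units; beyond the scatter), beyond it. Compound 4 `CC(C)(C)c1ccc(C(=O)N2CCC3(CC2)C(=O)N(CC(=O)NCCCCNS(C)(=O)=O)CN3c2ccccc2)cc1` has not yet been measured. It differs from compound 3 in one place: (4-(methanesulfonamido)butyl)amino in place of 2-(2-hydroxyethyl)piperidin-1-yl on a carbonyl carbon. For the measured compounds named here, no measured step covers this particular exchange. The three steps that touch the same carbonyl carbon, a 2.4-fold lower number from compound 1 to compound 2 (0.38 log units; beyond the scatter), a 2.0-fold higher number from compound 1 to compound 3 (0.29 log units; within the scatter) and a 4.7-fold higher number from compound 2 to compound 3 (0.67 log units; beyond the scatter), are all modest, so exchanging the group on this carbonyl has so far shifted the numbers only a little, in both directions. On that basis the step of a 1.2-fold lower number from compound 3 to compound 4 (0.09 log units; within the scatter) is expected to remain within the scatter, with no clear direction. Compound 4 is therefore estimated at 5000 nM, with a range of 1500 nM to 15000 nM in this assay.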

Compound 4, half-maximal inhibitory concentration: 4500 nM
For compound 4 the middle estimate is 1.1-fold (0.05 log units) above the measured one; measured number inside the range.
By their numbers in this assay, from the lowest: compound 2; then compounds 1, 4 and 3 (each within the scatter of the next).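

In this assay the ring-free (4-(methanesulfonamido)butyl)amino chain does about as well as the ring-bearing groups on this carbonyl carbon, with a 1.4-fold lower number from compound 3 to compound 4 (0.13 log units; within the scatter) and a 1.5-fold higher number from compound 1 to compound 4 (0.16 log units; within the scatter) so a piperidine ring at this place is not required to hold this level among the compounds shown. Compound 2 goes against this picture of a flat position, since a 3.5-fold higher number from compound 2 to compound 4 (0.54 log units; beyond the scatter) and its (2,2,6,6-tetramethylpiperidin-4-yl)oxy group remains the only one that stands clearly apart. No supporting data bear on why these numbers fall as they do.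

The compounds shown leave open whether the butyl chain or its methanesulfonamido end sets the result. A plain butylamino group, or a butyl chain ending in a carboxylic acid or a free amine, would separate the two.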